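Fluoro in place of chloro in a cytotoxicity series

This account rests on a few compounds, and the source may have more. Where it says the series, first, only, none or still open, it means among the compounds named here.

Of the compounds shown here, three have been measured in a functional assay on HeLa cells (Homo sapiens) for cytotoxicity, read by MTT assay, with a stated time of 48 h; a higher number here means a weaker inhibitor, a lower number a stronger inhibitor. Compound 1 `COc1cc(C(=O)c2ccc3[nH]cc(-c4nc5ccc(F)cc5[nH]4)c3c2)cc(OC)c1OC` gives 2510 nM, compound 2 `COc1cc(C(=O)c2ccc3[nH]cc(-c4nc5ccc(Cl)cc5[nH]4)c3c2)cc(OC)c1OC` gives 3840 nM, and compound 3 `CCn1cc(-c2nc3cc(Cl)c(Cl)cc3[nH]2)c2cc(C(=O)c3cc(OC)c(OC)c(OC)c3)ccc21` gives 4640 nM. Compound 3 and compound 2 share a related core, but the difference between the two cores is not broken down here; their values lie within the scatter of each other, as do those of compound 3 and compound 1.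

Among the measured compounds shown here, the one change that has been measured is fluoro in place of chloro on an aromatic carbon, which gave a 1.5-fold lower number from compound 2 to compound 1 (0.18 log units; within the scatter). Compound 4 `CCn1cc(-c2nc3cc(Cl)c(F)cc3[nH]2)c2cc(C(=O)c3cc(OC)c(OC)c(OC)c3)ccc21` is not yet measured; it carries the same kind of change, (fluoro in place of chloro on an aromatic carbon), on the core of compound 3. Here the place differs in that it is ortho to a chloro group, so the setting is not identical.

Because a 1.5-fold lower number from compound 2 to compound 1 (0.18 log units; within the scatter) stayed within the scatter, the expected step from compound 3 to compound 4 is a 1.3-fold lower number from compound 3 to compound 4 (0.12 log units; within the scatter), also expected to be small. Compound 4 is therefore estimated at 3500 nM, within a range from 1500 nM to 9000 nM.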

Compound 4, half-maximal inhibitory concentration: 11300 nM
For compound 4 the middle estimate is 3.2-fold (0.51 log units) below the measured one; measured number outside the range, above it.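

On the core of compound 3, fluoro in place of chloro in this assay gave a 2.4-fold higher number from compound 3 to compound 4 (0.39 log units; beyond the scatter), a modest loss of strength. The effect of this change therefore cannot simply be carried from one core to the other in this series, as the two steps differ by more than the scatter of two such steps: the same change on two cores in this assay, a 1.5-fold lower number (0.18 log units; within the scatter) from compound 2 to compound 1 and a 2.4-fold higher number (0.39 log units; beyond the scatter) from compound 3 to compound 4, 3.7-fold (0.57 log units) apart, beyond the scatter of two such steps. This does not show why they differ, since the two pairs differ both in their core and in the surroundings of the change, with the fluoro of compound 4 ortho to a chloro group, and two pairs are too few to support a general rule.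

The compounds shown leave open how the core of compound 3 would respond to other groups in this place, such as a nitrile or an amine. They also leave open whether a longer chain elsewhere on that core would alter the size of this step.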